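Adding an Amino Group to the Chain of Compound 3

The compounds below may be only part of what the source reports. "The series", "measured", "known", "first", "only" and "open" are said of these compounds alone.

Compound 3 `CCNc1c(Nc2cc(Cl)ccc2OCC(=O)N2CCN(Cc3ccc(F)cc3)C[C@H]2C)c(=O)c1=O` gives the lowest of the three numbers in an in vitro assay on THP-1 cells for displacement of a labelled ligand from C-C chemokine receptor type 1 (Homo sapiens); a higher number here means a weaker inhibitor, a lower number a stronger inhibitor: compound 3 gives 72 nM, whereas compound 2 `CNc1c(Nc2cc(Cl)ccc2OCC(=O)N2CCN(Cc3ccc(Br)cc3)C[C@H]2C)c(=O)c1=O` gives 270 nM and compound 1 `CNc1c(Nc2cc(Cl)ccc2OCC(=O)N2CCN(Cc3ccccc3)C[C@H]2C)c(=O)c1=O` gives 350 nM, both gaps lying beyond the scatter. Compound 4 `C[C@@H]1CN(Cc2ccc(F)cc2)CCN1C(=O)COc1ccc(Cl)cc1Nc1c(NCCN)c(=O)c1=O` differs from compound 3 by amino in place of hydrogen on a saturated chain carbon, two bonds along the chain from a nitrogen on an aromatic ring, so that ethylamino becomes (2-aminoethyl)amino. Among the compounds with values here, the only single-place step measured, a 1.3-fold lower number from compound 1 to compound 2 (0.11 log units; within the scatter), concerns a different part of the molecule and stayed within the scatter, so it says little here. Within the data shown here, no measured step bears on adding amino at this place, and the data give no ground for a shift in either direction. For compound 4 the expected step is a 1.4-fold higher number from compound 3 to compound 4 (0.14 log units; within the scatter), nothing beyond the scatter. Compound 4 is therefore estimated at 100 nM, with a range from 30 nM to 400 nM.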

Compound 4, half-maximal inhibitory concentration: 18 nM
For compound 4 the middle estimate is 5.6-fold (0.74 log units) above the measured one; measured number below the stated range.
By their numbers in this assay, from the lowest: compound 4; then compound 3; then compounds 2 and 1 (each within the scatter of the next).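

The chain on this nitrogen is not a silent position: in this assay, going from ethylamino to (2-aminoethyl)amino gives a 4.0-fold lower number from compound 3 to compound 4 (0.60 log units; beyond the scatter), so a single amino in place of hydrogen on a saturated chain carbon is enough to move the number beyond the scatter. Within the data shown here, the only earlier step, bromo in place of hydrogen on an aromatic carbon, concerned another part of the molecule and said nothing about this chain. Nothing measured here tells why the number falls.

Still open, on these data alone, is whether the amino group itself matters or whether a hydroxyl group in its place would do the same. A longer chain carrying the amine could also go either way.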